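Removing a Chloro Group from a Quinoline-Piperazine Isatin Series

The source may hold more compounds than are shown below. What is called first, only, known or untested is meant among the compounds shown, and "the series" means these compounds.

The measured compounds and their numbers in an ADME assay on MCF-10A cells (Homo sapiens) for cytotoxicity, read by sulforhodamine B assay, with a stated time of 48 h (on this read-out lower numbers stand for stronger inhibition of growth and higher numbers for weaker inhibition of growth), are:
compound 1, `O=C1C(=O)N(CN2CCN(c3ccnc4cc(Cl)ccc34)CC2)c2cc(Br)ccc21`, 18000 nM;
compound 2, `NC(=S)N/N=C1/C(=O)N(CN2CCN(c3ccnc4cc(Cl)ccc34)CC2)c2cccc(Cl)c21`, 19800 nM;
compound 3, `NC(=S)N/N=C1/C(=O)N(CN2CCN(c3ccnc4cc(C(F)(F)F)ccc34)CC2)c2cccc(Cl)c21`, 51700 nM.

Compound 3 stands at the highest number of the three in this assay. For the measured compounds named here, its nearest neighbour is compound 2, and the one step between them, a 2.6-fold higher number from compound 2 to compound 3 (0.42 log units; beyond the scatter), is the only single-point change measured here. Compound 1 differs from compound 3 in more than one place, so only the two values can be compared, not a step.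

Compound 4, `NC(=S)N/N=C1/C(=O)N(CN2CCN(c3ccnc4cc(C(F)(F)F)ccc34)CC2)c2ccccc21`, arises from compound 3 by hydrogen in place of chloro on an aromatic carbon. Going by the values given here, no measured step bears directly on this change: the one step on record concerns a different ring and a different group. With nothing to point to either direction, compound 3 remains the best guide, and a step in this assay of no more than the usual scatter is expected. The expected step is a 1.3-fold lower number from compound 3 to compound 4 (0.11 log units; within the scatter). Compound 4 is therefore estimated at 40000 nM, with a range from 15000 nM to 100000 nM.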

Compound 4, concentration for 50% growth inhibition: 22600 nM
Compound 4: middle estimate off by 1.8-fold (0.25 log units), on the high side; the measured number falls inside the stated range.
By their numbers in this assay, from the lowest: compounds 1, 2 and 4 (each within the scatter of the next); then compound 3.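

In this assay, for the compounds shown here, the step of a 2.3-fold lower number from compound 3 to compound 4 (0.36 log units; beyond the scatter) is the first measured change on this aromatic carbon, as the only earlier step, a 2.6-fold higher number from compound 2 to compound 3 (0.42 log units; beyond the scatter), concerned a different group on a different ring. It shows that this position is not silent on this read-out: with the trifluoromethyl group held constant, hydrogen in place of chloro moves the number beyond the usual scatter, and the lower number lies on the hydrogen side. The data at hand offer no explanation for this step.

Going by these compounds, it remains open whether the same replacement would give a similar step with chloro in place of trifluoromethyl on the other ring. How a fluoro, methoxy or amino group on this aromatic carbon would compare with hydrogen and chloro is also left open.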